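The source may hold more compounds than are shown below. What is called first, only, known or untested is meant among the compounds shown, and "the series" means these compounds.

Working notes on the series. Compound 1 `Cc1nn(-c2ccccn2)c2cc(-c3ccc(CCC(=O)O)cc3)ccc12` sets the reference: in a functional assay on cells for agonist activity at Free fatty acid receptor 1 (Mus musculus), read by FLIPR and calcium flux, with a stated time of 5 min (on this read-out higher numbers stand for an effect only at larger amounts of compound and lower numbers for an effect already at smaller amounts), compound 1 gives 1400 nM, the lowest number of the three measured. Compound 2 `COc1cc(CCC(=O)O)ccc1-c1ccc2c(C)nn(-c3ccccn3)c2c1` gives 8200 nM in this assay, and compound 3 `Cc1nn(-c2ccccn2)c2cc(-c3ccc(CCC(=O)O)cc3C#N)ccc12` gives 6100 nM; the steps of a 5.9-fold higher number from compound 1 to compound 2 (0.77 log units; beyond the scatter) and a 4.4-fold higher number from compound 1 to compound 3 (0.64 log units; beyond the scatter) both lie beyond the scatter, while a 1.3-fold lower number from compound 2 to compound 3 (0.13 log units; within the scatter) does not. Compound 4 `Cc1nn(-c2ccccn2)c2cc(-c3ccc([C@H]4C[C@H]4C(=O)O)cc3)ccc12` carries the change (2-carboxycyclopropyl in place of 2-carboxyethyl on an aromatic carbon). For the measured compounds named here, no measured step touches this part of the molecule; the two steps from compound 1 concern only substituents on the aromatic ring and give no guide to the acid-bearing chain. With nothing comparable to lean on, no step beyond the scatter is expected, so compound 4 is estimated at 1400 nM (range 450 nM to 4500 nM), an expected step of no change at the digits printed from compound 1 to compound 4 (within the scatter).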

Compound 4, half-maximal effective concentration: 19000 nM
Beside the measured number, compound 4's estimate is 14-fold (1.13 log units) below it; measured number outside the range, above it.
By their numbers in this assay, from the lowest: compound 1; then compounds 3 and 2 (each within the scatter of the next); then compound 4.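

For the compounds shown here, putting 2-carboxycyclopropyl in place of 2-carboxyethyl gives a 14-fold higher number from compound 1 to compound 4 (1.13 log units; beyond the scatter) in this assay, the largest step so far. The acid-bearing chain is therefore a sensitive position, and on this read-out the change moves the number further than either aromatic substituent step from compound 1 does. Nothing at hand explains this step.

As far as these compounds go, whether the step belongs to the three-membered ring itself or to its defined stereocentres stays open. Also open, from the compounds shown here alone, is how the opposite stereoisomer or a longer chain ending in a carboxylic acid would read.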